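Series notes: the step from compound 3 to compound 4

The source may report more compounds than this note shows. Statements on the series, on what has been measured and on what is new or still open speak of the compounds shown alone.

Three compounds have numbers in a functional assay on MDA-MB-231 cells (Homo sapiens) for cytotoxicity, read by MTT assay, with a stated time of 48 h; on this read-out lower numbers stand for stronger inhibition and higher numbers for weaker inhibition. Compound 1 `COc1cc(C2=NOC(c3cc(OC)c(OC)c(OC)c3)C2)ccc1O` gives 3600 nM. Compound 2 `COc1cc(-n2nnnc2-c2ccc(OCC3CC(c4ccc(C(F)(F)F)cc4)=NO3)c(N)c2)cc(OC)c1OC` gives 1750 nM. Compound 3 `COc1ccc(C2=NOC(COc3ccc(-c4nnnn4-c4cc(OC)c(OC)c(OC)c4)cc3N)C2)cc1N` gives 3000 nM. On these numbers compound 3 stands second highest of the three; its nearest neighbour is compound 1 and its furthest is compound 2, and both of those gaps lie within the scatter, so no order among the three can be claimed. Going by the values given here, the one single-site step recorded is a 1.7-fold higher number from compound 2 to compound 3 (0.23 log units; within the scatter), an exchange of the aryl group on a carbon with a double bond to nitrogen.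

Compound 4 `COc1ccc(C2=NOC(COc3ccc(-c4nnnn4-c4cc(OC)c(OC)c(OC)c4)cc3N)C2)cc1OC` is the next compound for this assay. Against compound 3 the change is methoxy in place of amino on an aromatic carbon. Among the compounds with values here, no measured step exchanges amino for methoxy anywhere; the only step on the same aryl group stayed within the scatter, and it replaced the whole group rather than this one substituent. No step beyond the scatter is therefore expected, and the expected step is no change at the digits printed from compound 3 to compound 4 (within the scatter). Compound 4 is estimated at 3000 nM, with a range from 1400 nM to 6500 nM.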

Compound 4, half-maximal inhibitory concentration: 3570 nM
The estimate for compound 4 lay 1.2-fold (0.08 log units) below the measured number; measured number inside the range.
By their numbers in this assay, from the lowest: compounds 2, 3, 4 and 1 (each within the scatter of the next, the first and the last beyond it).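

In this assay, going by these compounds alone, the first direct exchange at this position, methoxy in place of amino on an aromatic carbon ortho to a methoxy group, gives a 1.2-fold higher number from compound 3 to compound 4 (0.08 log units; within the scatter) and so shows the two groups reading alike here, even though the exchange removes a hydrogen-bond donor. Within the data shown here, the 3,4-dimethoxyphenyl group in place of 4-(trifluoromethyl)phenyl gives a 2.0-fold higher number from compound 2 to compound 4 (0.31 log units; beyond the scatter) as the only step beyond the scatter, whereas the 3-amino-4-methoxyphenyl group in the same place gave a 1.7-fold higher number from compound 2 to compound 3 (0.23 log units; within the scatter) and stayed within it. No available evidence accounts for either result.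

On these data alone, how a dimethylamino group, a chlorine atom or a longer ethoxy chain would read at this position remains open. As far as these compounds go, it is also open whether methoxy and amino read alike on other aryl groups.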